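The source may report more compounds than this note shows. Statements on the series, on what has been measured and on what is new or still open speak of the compounds shown alone.

Three compounds measured in an assay on Sf9 cells for inhibition of mitogen-activated protein kinase kinase kinase 14 variant S549D (Homo sapiens), with a stated time of 30 min, in the presence of a further agent that is not named here (on this read-out higher numbers stand for weaker inhibition and lower numbers for stronger inhibition), share one core and differ only in the group carried on a triple-bonded carbon. Compound 1 `C=CC(=O)NCC#Cc1ccc2ncn(-c3ccnc(N)n3)c2c1` gives 6310 nM in this assay, the second highest of the three numbers. Compound 3 `C#Cc1cccc(C#Cc2ccc3ncn(-c4ccnc(N)n4)c3c2)n1` gives 3160 nM, and compound 2 `C=Cc1cc(C#Cc2ccc3ncn(-c4ccnc(N)n4)c3c2)ccn1` gives 20000 nM. Compound 4 `Cc1ccnc(C#Cc2ccc3ncn(-c4ccnc(N)n4)c3c2)n1` has not yet been measured; it differs from compound 1 in one place: 4-methylpyrimidin-2-yl in place of ((vinylcarbonyl)amino)methyl on a triple-bonded carbon. Going by the values given here, two measured steps bear on such an exchange of the open chain for an aromatic ring. The step of a 2.0-fold lower number from compound 1 to compound 3 (0.30 log units; within the scatter) lies within the scatter, whereas the step of a 3.2-fold higher number from compound 1 to compound 2 (0.50 log units; beyond the scatter) is a modest move to a higher number. The two rings themselves are separated by a 6.3-fold lower number from compound 2 to compound 3 (0.80 log units; beyond the scatter), so these data do not settle whether a ring on that carbon raises or lowers the number. The expected step for compound 4 is a 1.3-fold lower number from compound 1 to compound 4 (0.10 log units; within the scatter), not clearly beyond the scatter. Compound 4 is therefore estimated at 5000 nM, within a range of 1500 nM to 16000 nM in this assay.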

Compound 4, half-maximal inhibitory concentration: 1580 nM
Estimate against measurement, compound 4: 3.2-fold (0.50 log units) above; measured number inside the range.
By their numbers in this assay, from the lowest: compounds 4, 3 and 1 (each within the scatter of the next, the first and the last beyond it); then compound 2.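

In this assay, an aromatic ring on the triple-bonded carbon now gives a clear gain over the open chain, with 4-methylpyrimidin-2-yl in place of ((vinylcarbonyl)amino)methyl producing a 4.0-fold lower number from compound 1 to compound 4 (0.60 log units; beyond the scatter) and moving beyond the scatter, which compound 3 had not done against compound 1. The ring's identity also matters at this position: there is a 2.0-fold lower number from compound 3 to compound 4 (0.30 log units; within the scatter) and so no separation from compound 3, yet a 13-fold lower number from compound 2 to compound 4 (1.10 log units; beyond the scatter) is the largest step seen here. No measurement shown explains these differences.

As far as these compounds go, it remains open whether the methyl on the pyrimidine contributes to the number of compound 4, or whether an amine or a carboxylic acid at that place would keep it. From the compounds shown here alone, the effect of a longer chain between the triple-bonded carbon and the ring also remains open.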